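Three limits, one unreadable step, and a benzoyl newcomer

The source may hold more compounds than are shown below. What is called first, only, known or untested is meant among the compounds shown, and "the series" means these compounds.

Compound 1 `Cc1nnc(SCC(=O)c2ccc(Cl)cc2)n1N1C(=O)c2ccccc2C1=O`, compound 2 `C#CCSc1nnc(C)n1N1C(=O)c2ccccc2C1=O` and compound 3 `C=CCSc1nnc(CC)n1N1C(=O)c2ccccc2C1=O` share a core and differ only in the group on a saturated chain carbon bound to a sulfur. In a functional assay on PC-3M cells (Homo sapiens) for cytotoxicity, read by MTT assay, with a stated time of 48 h (on this read-out lower numbers stand for stronger inhibition and higher numbers for weaker inhibition), compound 1 gives > 200000 nM, which is a limit of the assay rather than a number. Compound 2 also reaches only the limit > 200000 nM. Compound 3 stands at the limit > 200000 nM as well, so its place among the measured values is simply the one where all three sit, namely (the limit of > 200000 nM in this assay, at which 3 of the 3 values shown sit). Among the measured compounds shown here, the single step between measured compounds that changes one place, a step that the two limits leave unreadable from compound 1 to compound 2, has no readable size; both of its ends are limits.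

Compound 4 `CCc1nnc(SCC(=O)c2ccccc2)n1N1C(=O)c2ccccc2C1=O` has not yet been measured. Against compound 3 it shows (benzoyl in place of vinyl on a saturated chain carbon bound to a sulfur). For the measured compounds named here, the only measured step that bears on this place is a step that the two limits leave unreadable from compound 1 to compound 2, and it offers no size and no direction. The step expected in this assay is therefore a step that the limit leaves unreadable from compound 3 to compound 4, none beyond the scatter, with a good chance that compound 4 again reports only a limit. Compound 4 is estimated at 300000 nM, within a range from 80000 nM to 1000000 nM.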

Compound 4, half-maximal inhibitory concentration: > 200000 nM
Compound 4: only a limit was reported; the forecaster's own chance of this, stated with the estimate: 80%; the middle value is on the limit's open side.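

In this assay compound 4 gives > 200000 nM, which is a limit and not a number. Compound 3 and compound 4 both end at limits, so the step between them cannot be read. The compounds shown leave open whether any group at this place on the shared core would give a measurable value in this assay.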